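2-Nitrophenyl in place of 3-chlorophenyl on the shared core

The compounds below may be only part of what the source reports. "The series", "measured", "known", "first", "only" and "open" are said of these compounds alone.

In a physicochemical assay, with a stated time of 6 min (a lower number here means a stronger inhibitor, a higher number a weaker inhibitor), compound 1 `O=C(Nc1ccc(F)cc1)Nc1nc(-c2cc3ccccc3o2)cs1` gives 1130 nM. Compound 2 `O=C(Nc1ccc(Br)cc1)Nc1nc(-c2cc3ccccc3o2)cs1` gives only a limit of the assay, > 200000 nM. Compound 3 `O=C(Nc1cccc(Cl)c1)Nc1nc(-c2cc3ccccc3o2)cs1` gives 14100 nM, the higher of the two actual numbers. Compound 4 `O=C(Nc1nc(-c2cc3ccccc3o2)cs1)Nc1ccccc1[N+](=O)[O-]` carries 2-nitrophenyl in place of 3-chlorophenyl on an amide-type nitrogen. Two measured changes of the group on that nitrogen bear on it: a 12-fold higher number from compound 1 to compound 3 (1.10 log units; beyond the scatter) and an at least 14-fold lower number from compound 2 to compound 3 (1.15 log units; beyond the scatter). Both are large and beyond the scatter, but they run in opposite directions, so no firm direction follows. The expected step is a 1.4-fold lower number from compound 3 to compound 4 (0.15 log units; within the scatter), though a large move either way remains possible. For compound 4 the estimated value is 10000 nM, with an expected range from 1200 nM to 80000 nM.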

Compound 4, half-maximal inhibitory concentration: 20300 nM
Compound 4: the middle estimate sits 2.0-fold (0.31 log units) below what was measured, within the range that was stated.
By their numbers in this assay, from the lowest: compound 1; then compounds 3 and 4 (each within the scatter of the next). At a limit, above all of these: compound 2.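

In this assay, the result is a 1.4-fold higher number from compound 3 to compound 4 (0.16 log units; within the scatter), so on this amide-type nitrogen 2-nitrophenyl, with its hydrogen-bond acceptors, reads the same as 3-chlorophenyl, which has none. Compound 1 keeps the lowest number, and 4-fluorophenyl stays ahead of the new group: an 18-fold higher number from compound 1 to compound 4 (1.25 log units; beyond the scatter). Compound 2 remains a limit and not a number, so an at least 9.8-fold lower number from compound 2 to compound 4 (0.99 log units; beyond the scatter) is only a bound: the limit of > 200000 nM in this assay, at which 1 of the 4 values shown sits.

As far as these compounds go, whether an amine or a carboxylic acid on this phenyl ring would fall nearer compound 1 or compound 4 stays open. The substituent and its place on the ring also remain unseparated, since 3-chlorophenyl and 2-nitrophenyl differ in both.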